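Shifting the nitrile on the distal ring of compound 2

The compounds below may be only part of what the source reports. "The series", "measured", "known", "first", "only" and "open" are said of these compounds alone.

Compound 1 `CC(C)C[C@H](N)CN(C(=O)[C@@H]1C[C@H]1c1ccccc1)c1ccc(C2=CCCCC2)cc1` gives 1200 nM in a functional assay for agonist activity at G protein-coupled receptor 88 (Homo sapiens), read by HTRF and cAMP accumulation; a lower number here means that less compound is needed, a higher number that more compound is needed for the effect.
Compound 2 `CC(C)C[C@H](N)CN(C(=O)[C@@H]1C[C@H]1c1ccccc1)c1ccc(-c2ccc(C#N)cc2)cc1` gives 670 nM in this assay.

Within the data shown here, compound 2 holds the lowest of the two numbers so far, though its nearest neighbour, compound 1, sits within the scatter of it: the step of a 1.8-fold lower number from compound 1 to compound 2 (0.25 log units; within the scatter) does not separate the two. Compound 3 `CC(C)C[C@H](N)CN(C(=O)[C@@H]1C[C@H]1c1ccccc1)c1ccc(-c2cccc(C#N)c2)cc1` has not yet been measured. It differs from compound 2 by 3-cyanophenyl in place of 4-cyanophenyl on an aromatic carbon, the same atoms joined differently, with the nitrile moved from one position on the distal ring to another. Among the measured compounds shown here, no measured step bears directly on this change; the only step in hand, from compound 1 to compound 2, swaps a whole ring for another and stays within the scatter, which says little about moving a nitrile around one ring. With nothing in the data to indicate a shift in either direction, compound 3 is expected to give a number close to that of compound 2, with the step of a 1.2-fold higher number from compound 2 to compound 3 (0.08 log units; within the scatter) estimated to lie within the scatter. Compound 3 is therefore estimated at 800 nM, in a range from 350 nM to 2000 nM.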

Compound 3, half-maximal effective concentration: 4500 nM
Estimate against measurement, compound 3: 5.6-fold (0.75 log units) below; the whole stated range lies below it.
By their numbers in this assay, from the lowest: compounds 2 and 1 (each within the scatter of the next); then compound 3.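

In this assay, moving the nitrile around the aromatic ring proves to be no neutral change: 3-cyanophenyl and 4-cyanophenyl have the same atoms and the same counts of rings, donors and acceptors, yet the step is a 6.7-fold higher number from compound 2 to compound 3 (0.83 log units; beyond the scatter). Among these compounds, the earlier pair could not show this, since its single step stayed within the scatter and left cyclohex-1-en-1-yl and 4-cyanophenyl unseparated, whereas 3-cyanophenyl is the first group here to stand apart from cyclohex-1-en-1-yl, with a 3.8-fold higher number from compound 1 to compound 3 (0.57 log units; beyond the scatter). This rests on a single pair of isomers, so it marks the nitrile's place as mattering on this core only, and no measurement shown accounts for the shift.

From the compounds shown here alone, whether the higher number stays with another group in the place of the nitrile, such as a carboxylic acid, a methoxy group or an amine, remains open. Also open, going by these compounds, is whether a plain phenyl on the shared core would fall with compound 2 or with compound 3, which would show if the 4-cyanophenyl or the 3-cyanophenyl is the one departing from the unsubstituted ring.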